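The compounds below may be only part of what the source reports. "The series", "measured", "known", "first", "only" and "open" are said of these compounds alone.

Measured in a functional assay on MKN-45 cells (Homo sapiens) for cytotoxicity, read by MTT assay, with a stated time of 72 h; on this read-out lower numbers stand for stronger inhibition and higher numbers for weaker inhibition:
compound 1 `CN(C)CCn1cnnc1-c1cc(Oc2ccc(NC(=O)N/N=C/c3ccc(F)cc3)cc2F)ccn1` gives 1030 nM
compound 2 `CN(C)CCn1cnnc1-c1cc(Oc2ccc(NC(=O)N/N=C/c3c(O)ccc4ccccc34)cc2F)ccn1` gives 2020 nM
compound 3 `CN(C)CCn1cnnc1-c1cc(Oc2ccc(NC(=O)N/N=C/c3ccc(Cl)cc3)cc2F)ccn1` gives 570 nM

Compound 3 carries the lowest number of the three, but only its gap to compound 2, a 3.5-fold lower number from compound 2 to compound 3 (0.55 log units; beyond the scatter), is beyond the scatter; its gap to compound 1, a 1.8-fold lower number from compound 1 to compound 3 (0.26 log units; within the scatter), is within it. Compound 4 `CN(C)CCn1cnnc1-c1cc(Oc2ccc(NC(=O)N/N=C/c3ccc(O)c(F)c3)cc2F)ccn1` differs from compound 3 by 3-fluoro-4-hydroxyphenyl in place of 4-chlorophenyl on a carbon with a double bond to nitrogen. Among the compounds with values here, two measured steps bear on this: the halogen swap on the aromatic carbon, a 1.8-fold lower number from compound 1 to compound 3 (0.26 log units; within the scatter), stayed within the scatter, and the move to a hydroxyl-bearing aryl, a 2.0-fold higher number from compound 1 to compound 2 (0.29 log units; within the scatter), stayed within it too, while a 3.5-fold lower number from compound 2 to compound 3 (0.55 log units; beyond the scatter) was modest. A small shift toward a higher number, possibly within the scatter, is therefore expected in this assay, about a 2.1-fold higher number from compound 3 to compound 4 (0.32 log units; beyond the scatter). Compound 4 is estimated at 1200 nM, between 500 nM and 3000 nM.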

Compound 4, half-maximal inhibitory concentration: 1970 nM
Compound 4: middle estimate off by 1.6-fold (0.22 log units), on the low side; measured number inside the range.
By their numbers in this assay, from the lowest: compounds 3, 1, 4 and 2 (each within the scatter of the next, the first and the last beyond it).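

At the carbon with a double bond to nitrogen, 3-fluoro-4-hydroxyphenyl reads clearly worse than 4-chlorophenyl in this assay (a 3.5-fold higher number from compound 3 to compound 4 (0.54 log units; beyond the scatter)). It cannot be told apart from 2-hydroxynaphthalen-1-yl (a 1.0-fold lower number from compound 2 to compound 4 (0.01 log units; within the scatter)) or from 4-fluorophenyl (a 1.9-fold higher number from compound 1 to compound 4 (0.28 log units; within the scatter)), so compound 3 now separates from both hydroxyl-bearing compounds, while compound 1 separates from none. Nothing measured here accounts for these steps.

Still open, as far as these compounds go, is whether the hydroxyl or the fluoro carries the step from 4-chlorophenyl, and how a 4-aminophenyl or 4-carboxyphenyl group would read at this carbon.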